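Amide acyl variation on the shared core

A few compounds are considered here, and "the series" means these few. Any claim that something is new, unique, unknown or untested is made for them only; others in the source may bear on it.

Three measured compounds share one core and differ only in the acyl group on the amide nitrogen. In a functional assay on HT-29 cells (Homo sapiens) for antiproliferative activity, read by MTT assay, with a stated time of 72 h, tested at 10 uM (on this read-out lower numbers stand for less inhibition and higher numbers for more inhibition at the one concentration tested (going by the name of the read-out)), compound 1 `O=C(Nc1cc(Oc2ccc(Nc3nccc4[nH]cc(-c5ccc(F)cc5)c(=O)c34)cc2F)ccn1)C1CC1` gives 25.5%, compound 2 `CC(O)C(=O)Nc1cc(Oc2ccc(Nc3nccc4[nH]cc(-c5ccc(F)cc5)c(=O)c34)cc2F)ccn1` gives 47.8%, and compound 3 `CC(C)C(=O)Nc1cc(Oc2ccc(Nc3nccc4[nH]cc(-c5ccc(F)cc5)c(=O)c34)cc2F)ccn1` gives 83.4%. Compound 3 stands highest of the three, with a number 57.9 percentage points higher from compound 1 to compound 3 (beyond the scatter) and a number 35.6 percentage points higher from compound 2 to compound 3 (beyond the scatter) both beyond the scatter, while a number 22.3 percentage points higher from compound 1 to compound 2 (beyond the scatter) is modest. Compound 4 `CCCCC(=O)Nc1cc(Oc2ccc(Nc3nccc4[nH]cc(-c5ccc(F)cc5)c(=O)c34)cc2F)ccn1` is not yet measured; against compound 3 the change is butyl in place of isopropyl on a carbonyl carbon. Within the data shown here, no measured step swaps one open-chain alkyl for another: a number 57.9 percentage points higher from compound 1 to compound 3 (beyond the scatter) opens a ring and a number 35.6 percentage points higher from compound 2 to compound 3 (beyond the scatter) removes a hydroxy, so neither bears directly. In this assay a step within the scatter is therefore expected, a number 11.4 percentage points lower from compound 3 to compound 4 (beyond the scatter). Compound 4 is estimated at 72%, within 45% to 92%.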

Compound 4, a percentage reported as inhibition, at one concentration (the size of the read-out at that concentration, not a potency): -42.2%
The estimate for compound 4 lay 114.2 percentage points above the measured number; the whole stated range lies above it.
By their numbers in this assay, from the lowest: compound 4; then compound 1; then compound 2; then compound 3.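

At this position, on a carbonyl carbon whose other neighbour is an amide-type nitrogen, exchanging one open-chain alkyl for another is far from neutral in this assay and gives a number 125.6 percentage points lower from compound 3 to compound 4 (beyond the scatter) as the largest step in the series. Butyl also falls behind the other two acyl groups, with a number 90 percentage points lower from compound 2 to compound 4 (beyond the scatter) and a number 67.7 percentage points lower from compound 1 to compound 4 (beyond the scatter) so that compound 4 alone carries a negative number. No measured evidence bears on the reason for this drop.

Open, going by these compounds, is whether a propyl chain, a pentyl chain or a tert-butyl group would sit nearer compound 3 or compound 4. The compounds shown also do not separate chain length from branching.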